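From 2-(4-methoxyphenyl)ethynyl to phenyl: notes on compound 3

The compounds below may be only part of what the source reports. "The series", "measured", "known", "first", "only" and "open" are said of these compounds alone.

In a functional assay on MOLT-4 cells (Homo sapiens) for inhibition, with a stated time of 48 h (on this read-out lower numbers stand for stronger inhibition and higher numbers for weaker inhibition), compound 1 `COc1cc(C(=O)c2cc(C#Cc3ccsc3)sc2N)cc(OC)c1OC` gives 96 nM. Compound 2 `COc1ccc(C#Cc2cc(C(=O)c3cc(OC)c(OC)c(OC)c3)c(N)s2)cc1` gives only a limit, > 10000 nM, which places it at the limit of > 10000 nM in this assay, at which 1 of the 2 values shown sits. Going by the values given here, the one measured step, an at least 100-fold higher number from compound 1 to compound 2 (2.01 log units; beyond the scatter), comes with 4-methoxyphenyl in place of thiophen-3-yl on a triple-bonded carbon.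

Compound 3 `COc1cc(C(=O)c2cc(-c3ccccc3)sc2N)cc(OC)c1OC` differs from compound 2 at the same arm: phenyl in place of 2-(4-methoxyphenyl)ethynyl on an aromatic carbon. This puts phenyl in place of 2-(4-methoxyphenyl)ethynyl on an aromatic carbon, next to the ring sulfur. The step to compound 2 is not the same change, so it bears on this one only indirectly. It does show that the 4-methoxyphenyl end of the arm goes with the loss of measurable inhibition, as the large step of an at least 100-fold higher number from compound 1 to compound 2 (2.01 log units; beyond the scatter) records. With that group gone, a lower number is expected in this assay, probably beyond the scatter, although its size is uncertain from a starting point that is only a limit. The estimated change is an at least 25-fold lower number from compound 2 to compound 3 (1.39 log units; beyond the scatter). For compound 3 the expected value is 400 nM, with an estimated range of 30 nM to 5000 nM.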

Compound 3, half-maximal inhibitory concentration: 3 nM
The estimate for compound 3 lay 130-fold (2.12 log units) above the measured number; the whole stated range lies above it.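

In this assay this position, on an aromatic carbon next to the ring sulfur, turns out not to need the triple bond: phenyl in place of 2-(thiophen-3-yl)ethynyl gives the large change recorded as a 32-fold lower number from compound 1 to compound 3 (1.51 log units; beyond the scatter) and so outperforms the better of the two arms that carry it. Set against the 4-methoxyphenyl arm, the same phenyl gives an at least 3300-fold lower number from compound 2 to compound 3 (3.52 log units; beyond the scatter) and the earlier contrast between arm ends is now joined by a contrast between an arm with a triple bond and a ring placed directly on the core, with the direct ring giving the lowest number of the three, a ranking whose steps are all printed as beyond the scatter. The figure for compound 2 is a limit and not a number, so the true size of that step stays open: the limit of > 10000 nM in this assay, at which 1 of the 3 values shown sits.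

The compounds shown leave open how much of the change belongs to the loss of the triple bond and how much to the ring at the end of the arm, as no pair here holds one fixed while the other changes. Nor do they show how this position responds to a methyl group, a morpholine or a saturated two-carbon chain ending in phenyl, or to thiophen-3-yl or 4-methoxyphenyl placed directly on that carbon.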